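The compounds below may be only part of what the source reports. "The series", "measured", "known", "first", "only" and "open" are said of these compounds alone.

Compound 2 `CCn1cc(-c2cc(C(O)(C(F)(F)F)C(F)(F)F)cnc2N2CCN(S(=O)(=O)c3ccc(N)nc3)CC2)cn1` is measured in an ADME assay (liver) for metabolic stability, with Liver microsome (Homo sapiens) as the target, using microsomes and NADPH, with a stated time of 30 min, tested at 1 uM (a higher number here means faster removal of the compound, a lower number slower removal), and gives 20 mL.min-1.g-1. Among the measured compounds shown here, its only comparator is compound 1 `Nc1ccc(S(=O)(=O)N2CCN(c3ncc(C(O)(C(F)(F)F)C(F)(F)F)cc3C3CC3)CC2)cn1`, which in this assay gives 38 mL.min-1.g-1; the change from cyclopropyl to 1-ethyl-1H-pyrazol-4-yl on an aromatic carbon moved the number by a 1.9-fold lower number from compound 1 to compound 2 (0.28 log units; within the scatter), a step too small to separate the two compounds. Compound 3 `Nc1ccc(S(=O)(=O)N2CCN(c3ncc(C(O)(C(F)(F)F)C(F)(F)F)cc3-c3ccncc3)CC2)cn1` has not yet been measured in this assay. It differs from compound 2 at one place: pyridin-4-yl in place of 1-ethyl-1H-pyrazol-4-yl on an aromatic carbon. For the measured compounds named here, the one measured step bears only loosely on this swap, since it exchanged a different pair of groups at the same place, and it stayed within the scatter. With no step beyond the scatter to go on, compound 3 is expected to remain close to compound 2, with an estimated step of a 1.3-fold higher number from compound 2 to compound 3 (0.11 log units; within the scatter). The estimate for compound 3 in this assay is therefore 26 mL.min-1.g-1, within a range of 12 mL.min-1.g-1 to 55 mL.min-1.g-1.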

Compound 3, intrinsic clearance in microsomes: 15 mL.min-1.g-1
The estimate for compound 3 lay 1.7-fold (0.24 log units) above the measured number, and the stated range covers the measured number.
By their numbers in this assay, from the lowest: compounds 3, 2 and 1 (each within the scatter of the next, the first and the last beyond it).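

In this assay this position now yields its first step beyond the scatter: pyridin-4-yl in place of cyclopropyl gives a 2.5-fold lower number from compound 1 to compound 3 (0.40 log units; beyond the scatter) and separates two groups at this place, which the earlier pair could not do. Pyridin-4-yl in place of 1-ethyl-1H-pyrazol-4-yl gives a 1.3-fold lower number from compound 2 to compound 3 (0.12 log units; within the scatter) and so does not separate these two aromatic rings, although one is five-membered with 2 hetero atoms and the other six-membered with 1 hetero atom. No measurement shown here explains the difference between these groups.

The compounds shown leave open whether the nitrogen's place in the ring matters, as a pyridin-3-yl or pyridin-2-yl group at this position would show. They also leave open whether a phenyl ring, with no ring nitrogen, or a non-aromatic amine such as morpholine would fall in the same range.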